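Compound 4: aryl for benzyl on the ring nitrogen

The compounds below may be only part of what the source reports. "The series", "measured", "known", "first", "only" and "open" are said of these compounds alone.

Among the measured compounds shown here, compound 1 `CCc1cccc(NC(=O)c2cccc(/C=C3\CC(=O)N(Cc4ccccc4)C3=O)c2)c1` gives 80600 nM in an ADME assay on HCT-116 cells (Homo sapiens) for cytotoxicity, read by MTT assay, with a stated time of 72 h (on this read-out higher numbers stand for weaker inhibition and lower numbers for stronger inhibition), the second highest of the three numbers so far. Compound 2 `CCOc1ccc(NC(=O)c2cccc(/C=C3\CC(=O)N(Cc4ccccc4)C3=O)c2)cc1` gives 41700 nM and compound 3 `CCCCNC(=O)c1cccc(/C=C2\CC(=O)N(Cc3ccccc3)C2=O)c1` gives 95100 nM. Every measured step changes the group on the amide-type nitrogen: a 1.9-fold lower number from compound 1 to compound 2 (0.29 log units; within the scatter) and a 1.2-fold higher number from compound 1 to compound 3 (0.07 log units; within the scatter) stay within the scatter, while a 2.3-fold higher number from compound 2 to compound 3 (0.36 log units; beyond the scatter) is modest. Compound 4 `CCc1cccc(NC(=O)c2cccc(/C=C3\CC(=O)N(c4ccc(C)cc4)C3=O)c2)c1` differs from compound 1 at another place: 4-methylphenyl in place of benzyl on an amide-type nitrogen in a ring. For the measured compounds named here, no measured step touches this position, so nothing measured bears on the change directly. Since the three numbers lie close together, compound 4 is expected to show no step beyond the scatter, a 1.0-fold lower number from compound 1 to compound 4 (0.00 log units; within the scatter). Compound 4 is therefore estimated at 80000 nM, within 30000 nM to 200000 nM, with wide uncertainty.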

Compound 4, half-maximal inhibitory concentration: 41500 nM
Compound 4: the middle estimate sits 1.9-fold (0.29 log units) above what was measured; the measured number falls inside the stated range.
By their numbers in this assay, from the lowest: compounds 4, 2, 1 and 3 (each within the scatter of the next, the first and the last beyond it).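

The position on the ring nitrogen now has its first measured step: in this assay the change to 4-methylphenyl gives a 1.9-fold lower number from compound 1 to compound 4 (0.29 log units; within the scatter) and so stays within the scatter. Benzyl and 4-methylphenyl have the same counts of heavy atoms, donors and acceptors, so this step compares two differently joined groups of equal size. No evidence at hand bears on the reason for this result.

Going by these compounds, whether a carboxylic acid or an amine on this nitrogen would move the number beyond the scatter remains open. Also open, on these data alone, is whether the change would give a similar step on compound 2 or compound 3.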